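This account rests on a few compounds, and the source may have more. Where it says the series, first, only, none or still open, it means among the compounds named here.

Within this series, compound 3 `O=C(O)c1ccccc1-c1ccc(CCc2ncc(CCC3CCCCC3)[nH]2)cc1` stands apart: in an in vitro functional assay on cells for agonist activity at Bombesin receptor subtype-3 (Mus musculus), read by luminescence and calcium flux (a higher number here means that more compound is needed for the effect, a lower number that less compound is needed), compound 3 gives 33 nM, the highest of the three numbers measured. Compound 1 `O=C(O)c1ccccc1-c1ccc(CCc2ncc(CC3CCC3)[nH]2)cc1` gives 7.1 nM and compound 2 `Cc1ccccc1Cc1cnc(CCc2ccc(-c3ccccc3C(=O)O)cc2)[nH]1` gives 9.3 nM; the steps of a 4.6-fold higher number from compound 1 to compound 3 (0.67 log units; beyond the scatter) and a 3.5-fold higher number from compound 2 to compound 3 (0.55 log units; beyond the scatter) show that replacing either the cyclobutyl or the 2-methylphenyl group with cyclohexylmethyl moved the number upward by a modest but real amount, while a 1.3-fold higher number from compound 1 to compound 2 (0.12 log units; within the scatter) stayed within the scatter.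

Compound 4 `CC(C)(C)CCc1cnc(CCc2ccc(-c3ccccc3C(=O)O)cc2)[nH]1` has not yet been measured. It differs from compound 3 by tert-butyl in place of cyclohexyl on a saturated chain carbon, two bonds along the chain from an aromatic carbon; the same difference, cut one bond further out, reads cyclohexylmethyl to neopentyl. Among the measured compounds shown here, no measured step changes a ring for an open branched group of this kind, so the two steps leading into compound 3 are the only guide: they suggest the cyclohexylmethyl end is the less favourable of those tried. Compound 4 is therefore expected to show a modest downward step, a 2.2-fold lower number from compound 3 to compound 4 (0.34 log units; beyond the scatter), in this assay. The estimate for compound 4 is 15 nM, with a range from 6 nM to 40 nM.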

Compound 4, half-maximal effective concentration: 6.2 nM
For compound 4 the middle estimate is 2.4-fold (0.38 log units) above the measured one, within the range that was stated.
By their numbers in this assay, from the lowest: compounds 4, 1 and 2 (each within the scatter of the next); then compound 3.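

In this assay, the change from cyclohexyl to tert-butyl at the end of the chain gives the first step down from compound 3 (a 5.3-fold lower number from compound 3 to compound 4 (0.73 log units; beyond the scatter)). This shows that the higher number of compound 3 does not follow from a saturated group at this distance from the aromatic carbon alone, since the 3,3-dimethylbutyl chain carries the same position without it. Neopentyl in place of 2-methylphenyl (a 1.5-fold lower number from compound 2 to compound 4 (0.18 log units; within the scatter)) and in place of cyclobutyl (a 1.1-fold lower number from compound 1 to compound 4 (0.06 log units; within the scatter)) leaves the number within the scatter, so three different groups cannot be told apart here, and nothing shown explains the difference.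

From the compounds shown here alone, whether the ring itself or the larger group counts remains open, and a cyclobutyl at the end of the longer chain would bear on that. How an amine or a hydroxyl at the chain end would read is also unknown.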